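Swapping naphthalen-1-yl for phenyl in compound 1

The source may hold more compounds than are shown below. What is called first, only, known or untested is meant among the compounds shown, and "the series" means these compounds.

In a functional assay on HCT-116 cells (Homo sapiens) for inhibition, read by sulforhodamine B assay, with a stated time of 48 h, tested at 50 uM (on this read-out lower numbers stand for less inhibition of growth and higher numbers for more inhibition of growth at the one concentration tested), compound 1 `COc1cc(/C=C/C(=O)/C=C/c2cccc3ccccc23)ccc1OCc1cn(CCCCCOc2cc(=O)oc3ccccc23)nn1` gives 42%. Two relatives have been measured with it: compound 2 `COc1cccc(/C=C/C(=O)/C=C/c2ccc(OCc3cn(CCCCOc4cc(=O)oc5ccccc45)nn3)c(OC)c2)c1` gives 44%, and compound 3 `COc1cc(/C=C/C(=O)/C=C/c2ccccc2)ccc1OCc1cn(CCCCOc2cc(=O)oc3ccccc23)nn1` gives 34%. Compound 1 lies within the usual scatter of both, so these numbers give it no clear rank.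

The next compound to consider is compound 4 `COc1cc(/C=C/C(=O)/C=C/c2ccccc2)ccc1OCc1cn(CCCCCOc2cc(=O)oc3ccccc23)nn1`, which keeps the rest of compound 1 and alters one group: phenyl in place of naphthalen-1-yl on a double-bonded chain carbon bound to a double-bonded chain carbon. Put simply, this is phenyl in place of naphthalen-1-yl on a double-bonded chain carbon bound to a double-bonded chain carbon.

Among the compounds with values here, no measured pair tests this exact swap. The nearest evidence is a number 10 percentage points lower from compound 2 to compound 3 (within the scatter), which comes from hydrogen in place of methoxy on an aromatic carbon. That change also removes a substituent from an aromatic group, and its size does not exceed the scatter. Although it differs from compound 4 elsewhere, compound 3 carries the phenyl group too and gives 34%.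

On this evidence, a small downward move that stays inside the scatter seems most likely. The expected step is a number 6 percentage points lower from compound 1 to compound 4 (within the scatter). For compound 4 the estimated value is 36%, with an expected range from 26% to 46%.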

Compound 4, percent growth inhibition at one concentration: 24%
Beside the measured number, compound 4's estimate is 12 percentage points above it; the whole stated range lies above it.
By their numbers in this assay, from the lowest: compounds 4, 3, 1 and 2 (each within the scatter of the next, the first and the last beyond it).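

In this assay, the swap of naphthalen-1-yl for phenyl gives a number 18 percentage points lower from compound 1 to compound 4 (beyond the scatter) and is the first step among these compounds to pass beyond the scatter, since the earlier step between compound 2 and compound 3 stayed inside it. The place on a double-bonded chain carbon bound to a double-bonded chain carbon therefore responds to this change: with everything else held constant, going from two six-membered aromatic rings of carbon to one goes with less inhibition of growth at the one concentration tested. Nothing here explains this drop, as no measurement of any property of these compounds bears on it.

This rests on one pair at one concentration, so it cannot separate the loss of the second ring from the loss of the four carbon atoms as such, nor say how far the trend would run. As far as these compounds go, how this place would respond to an amine, a carboxylic acid or a ring carrying nitrogen, such as pyridinyl or quinolinyl, in place of naphthalen-1-yl remains open.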